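Swapping a Propyl Tail for a Chlorobenzyl Group

The source may hold more compounds than are shown below. What is called first, only, known or untested is meant among the compounds shown, and "the series" means these compounds.

Compound 1, `CCCN1CCC(C(=O)Nc2cc(Cl)c(N)cc2OC)CC1`, carries a short ethyl group on a saturated chain carbon bound to an amine nitrogen in a ring. In a functional assay on the whole organism for antagonist activity, with Mus musculus as the target (a higher number here means that more compound is needed for the effect, a lower number that less compound is needed), compound 1 returns only a limit, > 10 mg/kg, not a measured number. That is the limit of > 10 mg/kg in this assay, at which 1 of the 3 values shown sits. Compound 2, `CCOc1ccc(CN2CCC(C(=O)Nc3cc(Cl)c(N)cc3OC)CC2)cc1`, gives 6.3 mg/kg in this assay. Compound 3, `COc1cccc(CN2CCC(C(=O)Nc3cc(Cl)c(N)cc3OC)CC2)c1`, also returns only a limit, > 4 mg/kg. That is the limit of > 4 mg/kg in this assay, at which 1 of the 3 values shown sits.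

The unmeasured compound 4, `COc1cc(N)c(Cl)cc1NC(=O)C1CCN(Cc2cccc(Cl)c2)CC1`, differs from compound 1 at a single spot: 3-chlorophenyl in place of ethyl on a saturated chain carbon bound to an amine nitrogen in a ring. Of the measured steps, an at least 1.5-fold lower number from compound 1 to compound 2 (0.20 log units; that floor lies within the scatter) is the one that reads, and it shows that placing an aromatic ring at this position lowers the dose needed. The steps a step that the two limits leave unreadable from compound 1 to compound 3 and a step that the limit leaves unreadable from compound 2 to compound 3 cannot be sized. With one readable step pointing downward and two unreadable ones, the expectation for compound 4 is a lowering of the same modest kind, while the limit on compound 1 leaves the true size uncertain.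

Compound 4 is expected to come in near 5 mg/kg, with a plausible range from 2 mg/kg to 15 mg/kg. That expected step is an at least 2.0-fold lower number from compound 1 to compound 4 (0.30 log units; that floor lies within the scatter).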

Compound 4, dose for half-maximal effect: > 4 mg/kg
Compound 4: only a limit was reported; the forecaster's own chance of this, stated with the estimate: 35%; the middle value lies beyond the limit too.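

In this assay compound 4 gives > 4 mg/kg, which is a limit and not a number. None of the steps to compound 4 from compound 1, compound 2 or compound 3 can be read. The compounds shown leave open whether 3-chlorobenzyl in place of propyl changes the dose needed, and by how much.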